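The compounds below may be only part of what the source reports. "The series", "measured", "known", "first", "only" and "open" are said of these compounds alone.

Measured compounds and their values:

Compound 1 `CCc1cc(=O)c2ccc(OCc3ccccc3)c(C)c2o1`, in a functional assay on KB cells (Homo sapiens) for antiproliferative activity, read by sulforhodamine B assay, with a stated time of 72 h; a higher number here means a weaker inhibitor of growth, a lower number a stronger inhibitor of growth: > 33900 nM, a limit of the assay, not a number.
Compound 2 `CCc1cc(=O)c2ccc(OCc3cccc(C(F)(F)F)c3)c(C)c2o1`, in this assay: > 27600 nM, again a limit of the assay.
Compound 3 `CCc1oc2c(C)c(OCc3ccccc3)ccc2c(=O)c1Br`, in this assay: > 26700 nM, again a limit of the assay.

Compound 3 therefore stands on no number at all: its value is a limit, as are the other two values shown, and no order among the three compounds can be read from them. The two steps that have been measured share this fate. The step from compound 1 to compound 2 is a step that the two limits leave unreadable from compound 1 to compound 2, and the step from compound 1 to compound 3 is a step that the two limits leave unreadable from compound 1 to compound 3; the evidence on each is only a pair of limits (the limit of > 33900 nM in this assay, at which 1 of the 3 values shown sits, (the limit of > 27600 nM in this assay, at which 1 of the 3 values shown sits), (the limit of > 26700 nM in this assay, at which 1 of the 3 values shown sits)).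

Compound 4 `CCc1oc2c(C)c(OCc3cccc(C(F)(F)F)c3)ccc2c(=O)c1Br` differs from compound 3 by trifluoromethyl in place of hydrogen on an aromatic carbon. Going by the values given here, the step that bears on this change is the one from compound 1 to compound 2, the same exchange of trifluoromethyl for hydrogen, and its size cannot be read. The expectation for compound 4 in this assay is thus no step beyond the scatter that can be foreseen, and most likely another limit rather than a number. Compound 4 is estimated at 40000 nM, within 15000 nM to 150000 nM. The step from compound 3 to compound 4 expected from this estimate is a step that the limit leaves unreadable from compound 3 to compound 4.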

Compound 4, concentration for 50% growth inhibition: > 22600 nM
Compound 4: no number, only a limit (the forecaster's own chance of this, stated with the estimate: 85%); the middle value does not contradict the limit.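

In this assay compound 4 gives > 22600 nM, a limit of the assay and not a number. Neither the step from compound 3 to compound 4 nor the step from compound 2 to compound 4 can be read, as both ends of each are limits. The compounds shown leave open whether trifluoromethyl or bromo changes growth inhibition at all.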